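The source may hold more compounds than are shown below. What is called first, only, known or untested is meant among the compounds shown, and "the series" means these compounds.

Measured in a functional assay on Jurkat cells (Homo sapiens) for cytotoxicity, with a stated time of 24 h; a lower number here means a stronger inhibitor, a higher number a weaker inhibitor:
- compound 1 `Nn1c(SCc2cccc([N+](=O)[O-])c2)nnc1-c1c[nH]c2ccccc12`: > 100000 nM
- compound 2 `Nn1c(SCc2ccc(F)cc2)nnc1-c1c[nH]c2ccccc12`: > 100000 nM

Compound 2 reads > 100000 nM, which is a limit of the assay and not a number. Compound 1 likewise reads > 100000 nM, also a limit. Among the compounds with values here, neither compound therefore gives a number, and the series so far offers (the limit of > 100000 nM in this assay, at which 2 of the 2 values shown sit).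

Compound 3 `COc1ccc(CSc2nnc(-c3c[nH]c4ccccc34)n2N)cc1` has methoxy in place of fluoro on an aromatic carbon, para to a large group: methoxy in place of fluoro on an aromatic carbon. Within the data shown here, the data hold no measured step between compounds to calibrate this change. No step beyond the scatter is expected in this assay, and a further reading at the limit is the likeliest outcome. The expected change is a number no higher from compound 2 to compound 3 (the limit leaves the size open). The estimate for compound 3 is 100000 nM, with an expected range of 40000 nM to 200000 nM.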

Compound 3, half-maximal inhibitory concentration: > 100000 nM
Compound 3 was reported as a limit; the forecaster's own chance of this, stated with the estimate: 80%; the middle value sits exactly at the limit.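

Compound 3 reads > 100000 nM, a limit and not a number. No step can be read from compound 2 to compound 3, with methoxy in place of fluoro. The compounds shown leave open whether any change on the shared core gives a number in this assay: the limit of > 100000 nM in this assay, at which 3 of the 3 values shown sit.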